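The source may report more compounds than this note shows. Statements on the series, on what has been measured and on what is new or still open speak of the compounds shown alone.

Compound 3, `CN(c1ccc(Cl)cc1)c1ncnc2c1CCC2`, carries a chloro group on its aryl ring; in a functional assay on MDA-MB-435 cells (Homo sapiens) for inhibition, read by sulforhodamine B assay, with a stated time of 48 h (a higher number here means a weaker inhibitor, a lower number a stronger inhibitor), compound 3 has a result recorded as "not determined" (no result reported), so it gives no fixed point of its own. The surrounding data come from two other compounds. Compound 2, `COc1ccc(N(C)c2ncnc3c2CCC3)cc1`, is the methoxy analogue on the same core, and in this assay compound 2 gives 43 nM. Compound 1, `Cc1nc2c(c(N(C)c3ccc(Cl)cc3)n1)CC(C)C2`, carries the same chloro group as compound 3 but also a methyl on its core, and in this assay compound 1 gives 2300 nM; compound 1 is therefore not a direct partner of compound 3, and the gap between compound 1 and compound 2 blends two changes.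

Compound 4, `CCOc1ccc(N(C)c2ncnc3c2CCC3)cc1`, differs from compound 3 by ethoxy in place of chloro on an aromatic carbon. Going by the values given here, since compound 3 has no number, no step can be computed. A gain in potency is expected for compound 4, in the direction of compound 2, because its value of 43 nM shows how a small alkoxy group at this place performs, while the weak compound 1 shows the chloro pattern only in combination with a core methyl. Compound 4 is expected to lie near 60 nM, within a range of 15 nM to 250 nM.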

Compound 4, half-maximal inhibitory concentration: 48.7 nM
Compound 4: middle estimate off by 1.2-fold (0.09 log units), on the high side; the range from low to high includes it.
By their numbers in this assay, from the lowest: compounds 2 and 4 (each within the scatter of the next); then compound 1.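

In this assay, methyl in place of hydrogen on the saturated chain carbon bound to the oxygen gives a 1.1-fold higher number from compound 2 to compound 4 (0.05 log units; within the scatter), so on an aromatic carbon para to a large group, ethoxy and methoxy cannot be told apart. Going by these compounds alone, this extends the single alkoxy value of compound 2 to a second alkoxy group on the shared core, while the step from chloro in compound 3 to ethoxy in compound 4 cannot be read. Nothing measured here gives a reason for this result.

The compounds shown leave open whether a longer chain such as butoxy, or an amine at this place, would stay within the same range. They also leave open how chloro performs on the shared core without the methyl of compound 1.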